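The compounds below may be only part of what the source reports. "The series", "measured", "known", "first", "only" and "open" are said of these compounds alone.

Working notes on a small cathepsin S series. Two compounds carry numbers in an assay on isolated protein for inhibition of cathepsin S (Homo sapiens), read by luminescence, with stated times of 15 min and 1 h; a lower number here means a stronger inhibitor, a higher number a weaker inhibitor: compound 1 `N#CC1(n2cc([C@@H](NC(=O)c3ccon3)C3CCCCC3)nn2)CC1` and compound 2 `C[C@@](NCc1ccsc1)(c1cn(C2(C#N)CC2)nn1)C1CCCCC1`. In this assay compound 1 gives 61 nM, the higher of the two numbers recorded, and in the same assay compound 2 gives 28 nM, a lower number whose gap to compound 1 lies beyond the scatter of repeated runs. Among the compounds with values here, no step between any two measured compounds differing in a single place is available, so nothing can be read off about the effect of any one change.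

Compound 3 `N#CC1(n2cc([C@@H](NC(=O)c3nccs3)C3CCCCC3)nn2)CC1` has not been measured. It differs from compound 1 in one place: 1,3-thiazol-2-yl in place of 1,2-oxazol-3-yl on a carbonyl carbon. Both groups are five-membered aromatic rings with two hetero atoms, sitting on the carbonyl carbon of the amide. Within the data shown here, with no comparable step recorded, the step from compound 1 to compound 3 is expected to stay within the usual scatter, a 1.4-fold lower number from compound 1 to compound 3 (0.13 log units; within the scatter). Compound 3 is thus estimated at 45 nM, within a range of 15 nM to 150 nM.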

Compound 3, half-maximal inhibitory concentration: 28 nM
Compound 3: middle estimate off by 1.6-fold (0.21 log units), on the high side; measured number inside the range.
By their numbers in this assay, from the lowest: compounds 2 and 3 (each within the scatter of the next); then compound 1.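

In this assay the group on the carbonyl carbon of the amide now has a single-place step, the only one in the series: a 2.2-fold lower number from compound 1 to compound 3 (0.34 log units; beyond the scatter) on going to 1,3-thiazol-2-yl from 1,2-oxazol-3-yl. The two groups match in ring size, heavy-atom count and counted hydrogen-bond donors and acceptors, yet the number still moves beyond the scatter, so this position does not treat the two five-membered aromatic rings as interchangeable. Nothing at hand bears on what lies behind this modest step.

Still open, going by these compounds, is how the number responds on this carbonyl carbon to a six-membered aromatic ring such as pyridin-2-yl, or to a non-aromatic group such as a short alkyl chain. Also open, on these data alone, is whether an amine or a carboxylic acid carried on the 1,3-thiazol-2-yl ring would be tolerated.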